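This account rests on a few compounds, and the source may have more. Where it says the series, first, only, none or still open, it means among the compounds named here.

In a functional assay on HeLa cells (Homo sapiens) for antiproliferative activity, read by MTT assay, with a stated time of 48 h (on this read-out higher numbers stand for weaker inhibition and lower numbers for stronger inhibition), compound 1 `Cc1ccc2nc(NC(c3cn(-c4ccccc4)nc3-c3cccc([N+](=O)[O-])c3)c3c(O)ccc4ccccc34)sc2c1` gives 7360 nM, compound 2 `O=[N+]([O-])c1ccc(-c2nn(-c3ccccc3)cc2C(Nc2nc3ccccc3s2)c2c(O)ccc3ccccc23)cc1` gives 6810 nM and compound 3 `COc1ccc2nc(NC(c3cn(-c4ccccc4)nc3-c3ccc(Cl)cc3)c3c(O)ccc4ccccc34)sc2c1` gives 5200 nM. Compound 3 thus stands within the usual scatter of both others, so these numbers do not separate the three. Compound 4 `COc1ccc(-c2nn(-c3ccccc3)cc2C(Nc2nc3ccc(OC)cc3s2)c2c(O)ccc3ccccc23)cc1` alters compound 3 in one place: methoxy in place of chloro on an aromatic carbon. This is methoxy in place of chloro on an aromatic carbon, turning 4-chlorophenyl into 4-methoxyphenyl. Among the compounds with values here, no measured pair yet differs in only one place, so the data offer no direct guide to this change. Taking compound 3 at 5200 nM as the anchor, no step beyond the scatter is expected in this assay, in either direction. The expected step is a 1.1-fold higher number from compound 3 to compound 4 (0.02 log units; within the scatter). For compound 4, the estimated value is 5500 nM, with an expected range of 2500 nM to 12000 nM.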

Compound 4, half-maximal inhibitory concentration: 9240 nM
Compound 4: the middle estimate sits 1.7-fold (0.23 log units) below what was measured; measured number inside the range.
By their numbers in this assay, from the lowest: compounds 3, 2, 1 and 4 (each within the scatter of the next).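

In this assay, 4-methoxyphenyl in place of 4-chlorophenyl gives a 1.8-fold higher number from compound 3 to compound 4 (0.25 log units; within the scatter). Within the data shown here, this is the first comparison here that isolates a single place, and it shows that this exchange on the aromatic carbon does not move the number outside the usual scatter of repeated measurements. No supporting measurement bears on this result. As far as these compounds go, whether an amine or a carboxylic acid at this position would give a step beyond the scatter remains open. So does whether this exchange would behave the same way with other groups elsewhere on the shared core.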